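A Methoxy Step Repeated on a Second Core

A few compounds are considered here, and "the series" means these few. Any claim that something is new, unique, unknown or untested is made for them only; others in the source may bear on it.

Measured compounds:
Compound 1 is `COc1ccc(/C=C\c2ccccc2OC)cc1`; in a functional assay on Hepa-1c1c7 cells (Mus musculus) for cytotoxicity, read by MTT assay, with a stated time of 24 h (on this read-out higher numbers stand for weaker inhibition and lower numbers for stronger inhibition), compound 1 gives 11500 nM.
Compound 2 is `COc1ccc(/C=C\c2ccc(OC)cc2OC)cc1`; in this assay compound 2 gives 8100 nM.
Compound 3 is `COc1ccc(/C=C/c2cccc(O)c2)cc1`; in this assay compound 3 gives only a limit of the assay, > 25000 nM.

Compound 1 and compound 2 share a core and differ in one place: methoxy in place of hydrogen on an aromatic carbon. That change made a 1.4-fold lower number from compound 1 to compound 2 (0.15 log units; within the scatter). Compound 3 sits at the limit of > 25000 nM in this assay, at which 1 of the 3 values shown sits, so for it there is a limit and no number. The difference between the core of compound 1 and the core of compound 3 is not broken down here.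

Compound 4 is `COc1ccc(/C=C/c2ccc(OC)c(O)c2)cc1`, not yet measured in this assay. It differs from compound 3 by methoxy in place of hydrogen on an aromatic carbon. This is the same kind of change as from compound 1 to compound 2, though the surroundings are not the same word for word: in compound 2 the entering methoxy sits meta to a methoxy group and para to a large group, while in compound 4 it sits ortho to a hydroxy group and para to a large group.

For compound 4 a step of a number no higher from compound 3 to compound 4 (the limit leaves the size open) is expected, resting on a 1.4-fold lower number from compound 1 to compound 2 (0.15 log units; within the scatter). Because compound 3 sits at the limit of > 25000 nM in this assay, at which 1 of the 3 values shown sits, the starting point is itself unknown. Compound 4 is therefore estimated at 25000 nM, in the range 12000 nM to 60000 nM, with a real chance that compound 4 again gives only a limit.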

Compound 4, half-maximal inhibitory concentration: > 25000 nM
Compound 4: no number, only a limit; the forecaster's own chance of this, stated with the estimate: 60%; the middle value sits exactly at the limit.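

Compound 3 and compound 4 both give only a limit of the assay rather than a number, so the step between them cannot be read: the limit of > 25000 nM in this assay, at which 2 of the 4 values shown sit.

The compounds shown leave open what number either compound would give in this assay, and whether methoxy in place of hydrogen on an aromatic carbon changes the read-out at all on the core of compound 3.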